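The compounds below may be only part of what the source reports. "The series", "measured", "known", "first", "only" and "open" are said of these compounds alone.

For the measured compounds named here, compound 2 `Cc1c(Cc2ccc(-c3ccccc3C#N)cc2)c(=O)oc2cc(OCC(O)CN3CCC(C(N)=O)CC3)ccc12` is the only compound of the pair with a number in an ADME assay on A549 cells (Homo sapiens) for cytotoxicity, read by CellTiter-Glo (on this read-out higher numbers stand for lower toxicity in this test and lower numbers for higher toxicity in this test), where compound 2 gives 33200 nM. Compound 1 `COC(=O)c1ccc(Cc2c(C)c3ccc(OCC(O)CN4CCC(C(N)=O)CC4)cc3oc2=O)cc1` is recorded in this assay only as a limit, (the limit of > 100000 nM in this assay, at which 1 of the 2 values shown sits), and compound 1 gives > 100000 nM. Going by the values given here, the single measured step, an at least 3.0-fold lower number from compound 1 to compound 2 (0.47 log units; beyond the scatter), concerns a different exchange. Compound 3 `Cc1c(Cc2ccc(-c3ccc(C(F)(F)F)cc3)cc2)c(=O)oc2cc(OCC(O)CN3CCC(C(N)=O)CC3)ccc12` differs from compound 2 by 4-(trifluoromethyl)phenyl in place of 2-cyanophenyl on an aromatic carbon. Among the compounds with values here, no measured step covers this change, so its direction cannot be read from the data. The step is therefore expected to stay within the scatter, a 1.1-fold lower number from compound 2 to compound 3 (0.04 log units; within the scatter). Compound 3 is estimated at 30000 nM, with a range from 10000 nM to 100000 nM.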

Compound 3, half-maximal cytotoxic concentration: > 100000 nM
Compound 3 gave a limit, no number; the forecaster's own chance of this, stated with the estimate: 25%; middle value at least 3.3-fold (0.52 log units) from the limit.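

In this assay, the exchange on this aromatic carbon gives an at least 3.0-fold higher number from compound 2 to compound 3 (0.47 log units; beyond the scatter), so the two aryl groups are not interchangeable here, and among the three compounds only the 2-cyanophenyl compound gives a number. Compound 3 thus stands at the limit of the assay, as compound 1 does: the limit of > 100000 nM in this assay, at which 2 of the 3 values shown sit. The step between compound 1 and compound 3 cannot be read, as both values are limits. On these data alone, it remains open whether a plain phenyl group, or a phenyl group carrying an amine, would give a number at this place.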